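The compounds below may be only part of what the source reports. "The series", "measured", "known", "first", "only" and "open" are said of these compounds alone.

Measured compounds: compound 1 `Cc1cc(=O)oc2cc(Sc3cccc(Cl)[n+]3[O-])ccc12`, 24500 nM in a functional assay on KBVIN cells (Homo sapiens) for antiproliferative activity, read by sulforhodamine B assay, with a stated time of 72 h; on this read-out lower numbers stand for stronger inhibition of growth and higher numbers for weaker inhibition of growth; compound 2 `Cc1cc(=O)oc2cc(SCc3ccncc3)ccc12`, > 35200 nM in this assay.

For compound 2 only a limit is known in this assay: the value > 35200 nM is the assay's limit, not a number, and the limit of > 35200 nM in this assay, at which 1 of the 2 values shown sits, shows where it sits. Compound 3 `Cc1cccc(CSc2ccc3c(C)cc(=O)oc3c2)c1` has not been measured; it differs from compound 2 by 3-methylphenyl in place of pyridin-4-yl on a saturated chain carbon bound to a sulfur. Within the data shown here, with no measured step to guide the size, no change beyond the usual scatter is expected for compound 3, and the estimated step of an at least 1.1-fold lower number from compound 2 to compound 3 (0.06 log units; that floor lies within the scatter) is expected to stay near the limit. Compound 3 is estimated at 30000 nM, within 8000 nM to 80000 nM.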

Compound 3, concentration for 50% growth inhibition: > 33700 nM
Compound 3 was reported as a limit (the forecaster's own chance of this, stated with the estimate: 50%); middle value at least 1.1-fold (0.05 log units) away from the limit.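

Among these compounds, compound 2 and compound 3 are both reported only as limits, so no step between them can be read. Going by these compounds, whether 3-methylphenyl and pyridin-4-yl differ at all in this setting stays open.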